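The source may hold more compounds than are shown below. What is called first, only, known or untested is meant among the compounds shown, and "the series" means these compounds.

Compound 1 `Cc1cc(-c2ccc(F)cc2)c(S(C)(=O)=O)cc1C(=O)N=C(N)N` gives 36 nM in a functional assay for inhibition of sodium/hydrogen exchanger (Oryctolagus cuniculus); on this read-out higher numbers stand for weaker inhibition and lower numbers for stronger inhibition.
Compound 2 `CSc1cc(C)c(C(=O)N=C(N)N)cc1S(C)(=O)=O` gives 6 nM in this assay.
Compound 3 `Cc1cc(Sc2cccc(Cl)c2)c(S(C)(=O)=O)cc1C(=O)N=C(N)N` gives 37 nM in this assay.

Compound 3 has the highest of the three numbers: the step of a 1.0-fold higher number from compound 1 to compound 3 (0.01 log units; within the scatter) lies within the scatter, while a 6.2-fold higher number from compound 2 to compound 3 (0.79 log units; beyond the scatter) lies beyond it. Compound 4 `Cc1cc(OCc2ccccc2)c(S(C)(=O)=O)cc1C(=O)N=C(N)N` differs from compound 3 by benzyloxy in place of (3-chlorophenyl)sulfanyl on an aromatic carbon. Both the leaving and the entering group carry one six-membered aromatic ring of carbon only. Going by the values given here, two measured steps bear on this: a 6.2-fold higher number from compound 2 to compound 3 (0.79 log units; beyond the scatter) shows that a small group on the sulfur gave a lower number, and a 1.0-fold higher number from compound 1 to compound 3 (0.01 log units; within the scatter) shows that two different aryl-bearing groups at this position gave the same number. The change to compound 4 keeps an aryl-bearing group, so in this assay the expected step of a 1.2-fold lower number from compound 3 to compound 4 (0.09 log units; within the scatter) is none beyond the scatter. Compound 4 is therefore estimated at 30 nM, in the range 8 nM to 120 nM.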

Compound 4, half-maximal inhibitory concentration: 28 nM
The estimate for compound 4 lay 1.1-fold (0.03 log units) above the measured number, within the range that was stated.
By their numbers in this assay, from the lowest: compound 2; then compounds 4, 1 and 3 (each within the scatter of the next).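

In this assay, benzyloxy joins the ring-bearing groups at this position, staying level with both (3-chlorophenyl)sulfanyl (a 1.3-fold lower number from compound 3 to compound 4 (0.12 log units; within the scatter)) and 4-fluorophenyl (a 1.3-fold lower number from compound 1 to compound 4 (0.11 log units; within the scatter)). Across these three groups, changing the atoms that attach the aromatic ring to the core therefore leaves the number within the scatter, while the methylsulfanyl of compound 2 stays apart (a 4.7-fold higher number from compound 2 to compound 4 (0.67 log units; beyond the scatter)). No evidence here gives a reason for either observation. As far as these compounds go, whether methoxy or an amine at this position would give a number close to compound 2 or to the ring-bearing compounds stays open.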